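A few compounds are considered here, and "the series" means these few. Any claim that something is new, unique, unknown or untested is made for them only; others in the source may bear on it.

Compound 1, `CCc1ccccc1-c1cccc(COc2ccc([C@H](CC(=O)O)c3nccn3C)cc2)c1`: 48 nM
Compound 2, `Cc1cc(Cl)ccc1-c1cccc(COc2ccc([C@H](CC(=O)O)c3nccn3C)cc2)c1C`: 240 nM

Both compounds were tested in an assay on CHO cells for agonist activity at Free fatty acid receptor 1 (Homo sapiens), read by luminescence, with a stated time of 20 s, in the presence of a further agent that is not named here; on this read-out higher numbers stand for an effect only at larger amounts of compound and lower numbers for an effect already at smaller amounts. Compound 1 gives the lower of the two numbers, and the gap to compound 2 lies beyond the usual scatter of this assay, so compound 1 is the more potent of the pair. Compound 3, `Cc1c(Cl)cccc1-c1cccc(COc2ccc([C@H](CC(=O)O)c3nccn3C)cc2)c1`, has not yet been measured. It differs from compound 1 in one place: 3-chloro-2-methylphenyl in place of 2-ethylphenyl on an aromatic carbon, on an aromatic carbon of a six-membered aromatic ring of carbon only, meta to a large group. Going by the values given here, compound 2 differs from compound 1 in more than one place, so its number gives no single step to lean on. The change from compound 1 to compound 3 is expected to cost a modest amount of potency, a 2.1-fold higher number from compound 1 to compound 3 (0.32 log units; beyond the scatter). Compound 3 is therefore estimated at 100 nM, most likely between 30 nM and 350 nM.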

Compound 3, half-maximal effective concentration: 61 nM
Compound 3: middle estimate off by 1.6-fold (0.21 log units), on the high side; the range from low to high includes it.
By their numbers in this assay, from the lowest: compounds 1 and 3 (each within the scatter of the next); then compound 2.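

In this assay, the step from 2-ethylphenyl to 3-chloro-2-methylphenyl is a 1.3-fold higher number from compound 1 to compound 3 (0.10 log units; within the scatter), so the two compounds cannot be told apart on this read-out. Going by these compounds alone, this is the first clean look at this position, since compound 2 differs from compound 1 in more than one place: here, one substituted phenyl group with the same count of heavy atoms stands in for another and potency holds, even with a chlorine added and the ethyl shortened to a methyl. No measurement at hand explains why these two groups read alike.

Still open, as far as these compounds go, is how 2-methylphenyl without the chlorine, or 3-chlorophenyl without the methyl, would read, so the share of each group in this result remains unknown. Equally open, from the compounds shown here alone, is whether a longer chain such as 2-propylphenyl would hold potency at this position.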